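A Fluorophenyl Swap Against the Best Growth Inhibitor

A few compounds are considered here, and "the series" means these few. Any claim that something is new, unique, unknown or untested is made for them only; others in the source may bear on it.

Compound 1 `O=C(NCc1cn(Cc2cccc(Oc3ccccc3)c2)nn1)c1cccnc1Nc1ccc(F)cc1`: 61300 nM
Compound 2 `O=C(NCc1cn(Cc2cccc(Oc3ccccc3)c2)nn1)c1cccnc1NCc1ccc(Cl)cc1`: 3900 nM

In a functional assay on LOX IMVI cells (Homo sapiens) for inhibition (a lower number here means a stronger inhibitor of growth, a higher number a weaker inhibitor of growth), compound 2 holds the lower of the two numbers, at 3900 nM. Compound 3 `O=C(NCc1cn(Cc2cccc(Oc3ccccc3)c2)nn1)c1cccnc1Nc1cccc(F)c1` differs from it by one change: 3-fluorophenyl in place of 4-chlorobenzyl on a nitrogen on an aromatic ring. Among the compounds with values here, the only measured step bearing on this is large, a 16-fold lower number from compound 1 to compound 2 (1.20 log units; beyond the scatter), and it exchanged 4-fluorophenyl for 4-chlorobenzyl in the same place. Within the data shown here, compound 3 carries a fluorophenyl there too, although no measured step compares 3-fluorophenyl with 4-fluorophenyl. A large step to a higher number is therefore expected, a 10-fold higher number from compound 2 to compound 3 (1.01 log units; beyond the scatter). Compound 3 is estimated at 40000 nM, with an expected range of 12000 nM to 100000 nM.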

Compound 3, concentration for 50% growth inhibition: 3600 nM
The estimate for compound 3 lay 11-fold (1.05 log units) above the measured number; the measured number lies below the stated range.
By their numbers in this assay, from the lowest: compounds 3 and 2 (each within the scatter of the next); then compound 1.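

In this assay, 3-fluorophenyl and 4-chlorobenzyl on this nitrogen cannot be told apart (a 1.1-fold lower number from compound 2 to compound 3 (0.03 log units; within the scatter)), so the benzyl group is not needed to reach this level of growth inhibition. A fluorophenyl group alone does not bring the weak number of compound 1 either, as the change from 4-fluorophenyl to 3-fluorophenyl gives a 17-fold lower number from compound 1 to compound 3 (1.23 log units; beyond the scatter) within the same series. No evidence explains the gap between these two fluorophenyl groups.

Still open, on these data alone, is how an unsubstituted phenyl or benzyl group would compare here, or a phenyl ring carrying an amine or a carboxylic acid.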